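Isobutyl for isopropyl on the amide of compound 3

A few compounds are considered here, and "the series" means these few. Any claim that something is new, unique, unknown or untested is made for them only; others in the source may bear on it.

In a functional assay on the whole organism with Mus musculus as the target (on this read-out lower numbers stand for an effect already at smaller amounts and higher numbers for an effect only at larger amounts of compound), compound 1 (`NC(=O)/C=C/c1cccc(C(F)(F)F)c1`) gives 42.9 mg/kg as a measured number. Compound 2 (`CN1C(=O)CCC1(O)c1ccc(C(F)(F)F)cc1`) gives > 200 mg/kg in this assay and this is a limit of the assay, not a number. Going by these compounds, compound 3 (`CC(C)NC(=O)CCC(=O)c1cccc(C(F)(F)F)c1`) gives > 200 mg/kg in this assay and this too is a limit, so its true place on the scale stays open. Among the measured compounds shown here, the series so far shows the limit of > 200 mg/kg in this assay, at which 2 of the 3 values shown sit, as its main feature.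

Compound 4 (`CC(C)CNC(=O)CCC(=O)c1cccc(C(F)(F)F)c1`) carries isobutyl in place of isopropyl on an amide-type nitrogen and otherwise matches compound 3. No measured step sizes this change, so only a small shift is expected, toward a lower dose if there is any shift at all. The expected step of an at least 1.1-fold lower number from compound 3 to compound 4 (0.04 log units; that floor lies within the scatter) is an estimate set against a limit and not against a number. For compound 4 the estimated dose is 180 mg/kg with an expected range of 70 mg/kg to 400 mg/kg and another limit remains quite possible.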

Compound 4, dose for half-maximal effect: > 200 mg/kg
Compound 4 was reported as a limit (the forecaster's own chance of this, stated with the estimate: 60%); middle value at least 1.1-fold (0.04 log units) from the limit.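

No step can be read from compound 3 to compound 4, as both values are limits and not numbers: the limit of > 200 mg/kg in this assay, at which 3 of the 4 values shown sit.

The compounds shown leave open where compound 3 and compound 4 truly lie on the scale, and whether isobutyl in place of isopropyl on the amide-type nitrogen shifts the dose at all.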